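Notes on 3-iodophenyl versus 4-iodophenyl amides

The compounds below may be only part of what the source reports. "The series", "measured", "known", "first", "only" and "open" are said of these compounds alone.

Measured in a functional assay on SK-OV-3 cells (Homo sapiens) for antiproliferative activity, read by MTT assay, with a stated time of 72 h; a lower number here means a stronger inhibitor, a higher number a weaker inhibitor
compound 1 `O=C(CCc1cccc2c1B(O)OC2)NC1CCCCC1` gives > 100000 nM as a limit
compound 2 `O=C(CCc1cccc2c1B(O)OC2)NCc1ccccc1` gives > 100000 nM as a limit
compound 3 `O=C(CCc1cccc2c1B(O)OC2)Nc1ccc(I)cc1` gives 51000 nM as a number

Only compound 3 gives a number, while the limit of > 100000 nM in this assay, at which 2 of the 3 values shown sit, accounts for the other two. Compound 4 `O=C(CCc1cccc2c1B(O)OC2)Nc1cccc(I)c1` differs from compound 3 by 3-iodophenyl in place of 4-iodophenyl on an amide-type nitrogen, with 3-iodophenyl in place of 4-iodophenyl on an amide-type nitrogen. The nearest measured steps are an at least 1.9-fold lower number from compound 1 to compound 3 (0.29 log units; that floor lies within the scatter) and an at least 1.9-fold lower number from compound 2 to compound 3 (0.29 log units; that floor lies within the scatter), and the size of a step that the two limits leave unreadable from compound 1 to compound 2 cannot be read. None of these moves the iodine, so no step beyond the scatter is expected in this assay, and the expectation rests on compound 3 at 51000 nM. The expected change is a 1.1-fold higher number from compound 3 to compound 4 (0.03 log units; within the scatter). Compound 4 is estimated at 55000 nM, with an expected range of 25000 nM to 100000 nM.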

Compound 4, half-maximal inhibitory concentration: 630 nM
Compound 4: the middle estimate sits 87-fold (1.94 log units) above what was measured; the whole stated range lies above it.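

Moving the iodine alone, with the same atoms joined differently, gives an 81-fold lower number from compound 3 to compound 4 (1.91 log units; beyond the scatter) and so shows that its place on the ring decides the read-out here, which no earlier step could show. The 3-iodophenyl group also gives an at least 150-fold lower number from compound 2 to compound 4 (2.20 log units; beyond the scatter) and an at least 150-fold lower number from compound 1 to compound 4 (2.20 log units; beyond the scatter) as the two wider changes on the amide-type nitrogen. Both of these are floors, as compound 1 and compound 2 each stand at a limit: the limit of > 100000 nM in this assay, at which 2 of the 4 values shown sit.

The compounds shown leave open whether a 3-bromophenyl or 3-methoxyphenyl amide would hold this level, and so whether iodine itself is needed at that place.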